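Ester in place of amide on the shared core

This account rests on a few compounds, and the source may have more. Where it says the series, first, only, none or still open, it means among the compounds named here.

Compound 3 `CN1CCN(C(=O)c2c(N)sc(-c3ccc(Cl)cc3)c2-c2ccc(Cl)cc2)CC1` gives 590 nM in a functional assay on A549 cells (Homo sapiens) for inhibition, read by sulforhodamine B assay, with a stated time of 72 h; a higher number here means a weaker inhibitor, a lower number a stronger inhibitor. Among the three numbers so far it stands second highest: compound 1 `Nc1sc(-c2ccc(Cl)cc2)c(-c2ccc(Cl)cc2)c1C(=O)NC1CCC(O)CC1` gives 250 nM, and the step of a 2.4-fold higher number from compound 1 to compound 3 (0.37 log units; beyond the scatter) is modest, while compound 2 `CCOC(=O)Nc1sc(-c2ccc(Cl)cc2)c(-c2ccc(Cl)cc2)c1C(=O)NC1CC1` gives 39800 nM, far weaker than either and differing from compound 1 in two places, so no single step is drawn from it. Compound 4 `COC(=O)c1c(N)sc(-c2ccc(Cl)cc2)c1-c1ccc(Cl)cc1` differs from compound 3 by methoxy in place of 4-methylpiperazin-1-yl on a carbonyl carbon. Within the data shown here, no measured step exchanges an amide for an ester; the only step on the carbonyl carbon, a 2.4-fold higher number from compound 1 to compound 3 (0.37 log units; beyond the scatter), replaces one carbonyl substituent with another and is small. The expected step in this assay is therefore a 2.5-fold higher number from compound 3 to compound 4 (0.41 log units; beyond the scatter), a loss beyond the scatter but uncertain. Compound 4 is estimated at 1500 nM, ranging from 300 nM to 8000 nM.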

Compound 4, half-maximal inhibitory concentration: 5040 nM
Compound 4: the middle estimate sits 3.4-fold (0.53 log units) below what was measured; the measured number falls inside the stated range.
By their numbers in this assay, from the lowest: compound 1; then compound 3; then compound 4; then compound 2.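

The carbonyl carbon tolerates exchange between the two amides far better than a move to the ester: in this assay the methoxy change gives an 8.5-fold higher number from compound 3 to compound 4 (0.93 log units; beyond the scatter) and a 20-fold higher number from compound 1 to compound 4 (1.30 log units; beyond the scatter), whereas the amide-to-amide step is only a 2.4-fold higher number from compound 1 to compound 3 (0.37 log units; beyond the scatter). Both amides, compound 1 and compound 3, therefore give lower numbers than the ester, compound 4.

Nothing available explains this loss. Going by these compounds, whether it follows from the ester link or from losing the larger ring stays open; a primary amide or a carboxylic acid on the same carbonyl carbon would help separate these readings.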